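Swapping trifluoromethyl for trifluoromethoxy on a urea

The source may hold more compounds than are shown below. What is called first, only, known or untested is meant among the compounds shown, and "the series" means these compounds.

Three thiourea and urea compounds have been tested in an assay on isolated protein for binding affinity to stress-70 protein, mitochondrial (Homo sapiens); on this read-out higher numbers stand for weaker binding and lower numbers for tighter binding. Compound 1 `CC1(C)CCNc2ccc(NC(=S)Nc3ccc(C(F)(F)F)cc3)cc21` gives 3300 nM. Compound 2 `CC1(C)CCNc2ccc(NC(=S)Nc3ccc(OC(F)(F)F)cc3)cc21` gives 5400 nM. Compound 3 `CN1c2ccc(NC(=O)Nc3ccc(C(F)(F)F)cc3)cc2C(C)(C)C(O)C1(C)C`, built on a different core, gives 700 nM, the lowest of the three numbers and beyond the scatter from both of the others. The difference between the core of compound 1 and the core of compound 3 is not broken down here.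

Compounds 1 and 2 differ in one place only: trifluoromethoxy in place of trifluoromethyl on an aromatic carbon. This change made a step of a 1.6-fold higher number from compound 1 to compound 2 (0.21 log units; within the scatter), so the two compounds cannot be told apart in this assay.

The unmeasured compound 4 `CN1c2ccc(NC(=O)Nc3ccc(OC(F)(F)F)cc3)cc2C(C)(C)C(O)C1(C)C` is related to compound 3 in exactly the same way: trifluoromethoxy in place of trifluoromethyl on an aromatic carbon. Since the surroundings of the changed position are described in the same words in both pairs, this is the same change, now made on the stronger-binding core. Among the compounds with values here, the only guide to its effect is the pair compound 1 to compound 2, where the step stayed within the scatter. On that basis the expected step is a 1.6-fold higher number from compound 3 to compound 4 (0.20 log units; within the scatter), a small move rather than a clear loss or gain. Within the data shown here, compound 4 is therefore estimated at 1100 nM, with a likely range from 500 nM to 2500 nM, since only one earlier example of the change is available and it was made on a different core.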

Compound 4, dissociation constant: 1100 nM
Beside the measured number, compound 4's estimate shows no gap at the digits printed, within the range that was stated.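

In this assay, putting trifluoromethoxy in place of trifluoromethyl on the second core gave a 1.6-fold higher number from compound 3 to compound 4 (0.20 log units; within the scatter), so on this core too the two compounds cannot be told apart. Set beside the earlier example, the change looks the same on both cores: the same change on two cores in this assay, a 1.6-fold higher number (0.21 log units; within the scatter) from compound 1 to compound 2 and a 1.6-fold higher number (0.20 log units; within the scatter) from compound 3 to compound 4, 1.0-fold (0.02 log units) apart, within the scatter of two such steps. In these two pairs, then, the swap carries from one core to the other as a step too small to read, but this does not show a real shift of any size, and two pairs cannot say whether the swap would stay this small on a further core or why it is small here.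

The compounds shown leave open what other groups on that aromatic carbon would do on either core, for example a nitrile, a methoxy group or an amine. They also leave open how a thiourea and a urea compare on one and the same core, as the thioureas and the ureas here also differ elsewhere in their structures.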